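Swapping a Benzoyl Ester for a Silyl Ether

The compounds below may be only part of what the source reports. "The series", "measured", "known", "first", "only" and "open" are said of these compounds alone.

Four compounds share one core. Compound 1 `O=C(OCC(CCO)n1cnc2c(Cl)nc(F)nc21)c1ccccc1` and compound 2 `CC(C)(C)[Si](C)(C)OCC(CCO)n1cnc2c(Cl)nc(F)nc21` carry fluoro on that core, while compound 3 `O=C(OCC(CCO)n1cnc2c(Cl)ncnc21)c1ccccc1` and compound 4 `CC(C)(C)[Si](C)(C)OCC(CCO)n1cnc2c(Cl)ncnc21` carry hydrogen in its place; the difference between the two cores is hydrogen in place of fluoro on an aromatic carbon. In a functional assay on SW480 cells (Homo sapiens) for antiproliferative activity, read by MTT assay, with a stated time of 48 h (a lower number here means a stronger inhibitor, a higher number a weaker inhibitor), compound 1 gives 7240 nM, and compound 2 gives 8020 nM. The change between them is a group of 7 heavy atoms (6 carbon, 1 silicon; no ring) in place of a group of 8 heavy atoms (7 carbon, 1 oxygen; one six-membered aromatic ring of carbon only), on an oxygen on a saturated carbon, and it made a 1.1-fold higher number from compound 1 to compound 2 (0.04 log units; within the scatter). Compound 3 gives only a limit of the assay, > 50000 nM, in this assay, the line at which its value sits being (the limit of > 50000 nM in this assay, at which 1 of the 3 values shown sits). Hydrogen in place of fluoro thus made an at least 6.9-fold higher number from compound 1 to compound 3 (0.83 log units; beyond the scatter). Compound 4 differs from compound 3 by a group of 7 heavy atoms (6 carbon, 1 silicon; no ring) in place of a group of 8 heavy atoms (7 carbon, 1 oxygen; one six-membered aromatic ring of carbon only), on an oxygen on a saturated carbon, the same change as that between compound 1 and compound 2, at the same place. Because that change made a 1.1-fold higher number from compound 1 to compound 2 (0.04 log units; within the scatter), a similarly small step is expected here, which the estimate expresses as a step that the limit leaves unreadable from compound 3 to compound 4 in this assay. Compound 4 is therefore expected near 60000 nM, between 25000 nM and 150000 nM, most likely again reported only as a limit.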

Compound 4, half-maximal inhibitory concentration: 31700 nM
Estimate against measurement, compound 4: 1.9-fold (0.28 log units) above; low and high end bracket the measured number.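

Carried to the hydrogen core, the swap of benzoyl for the silyl group rests on a limit for compound 3 and made an at least 1.5-fold lower number from compound 3 to compound 4 (0.19 log units; that floor lies within the scatter), so the silyl compound lost no measurable ground there, but the true size of this step stays unknown. Whether the swap acts the same way on both cores therefore remains unsettled: the same change on two cores in this assay, a 1.1-fold higher number (0.04 log units; within the scatter) from compound 1 to compound 2 and an at least 1.5-fold lower number (0.19 log units; that floor lies within the scatter) from compound 3 to compound 4; the limit leaves it open whether they differ

Hydrogen in place of fluoro, by contrast, now has a step of readable size in the silyl pair, a 4.0-fold higher number from compound 2 to compound 4 (0.60 log units; beyond the scatter), and it points the same way as in the benzoyl pair, although the two cannot be told apart: the same change on two cores in this assay, an at least 6.9-fold higher number (0.83 log units; beyond the scatter) from compound 1 to compound 3 and a 4.0-fold higher number (0.60 log units; beyond the scatter) from compound 2 to compound 4; the limit leaves it open whether they differ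

The compounds shown cover only these groups on the oxygen and on the aromatic carbon, so it stays open how far the pattern reaches beyond these four compounds. An acetyl group on that oxygen, or an amine or a methoxy group in place of fluoro, would show whether either trend holds for other groups.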